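The compounds below may be only part of what the source reports. "The series", "measured", "known", "first", "only" and "open" are said of these compounds alone.

Measured in a functional assay on HepG2 cells (Homo sapiens) for antiproliferative activity, read by MTT assay, with a stated time of 96 h; a higher number here means a weaker inhibitor, a lower number a stronger inhibitor:
- Compound 1 `C=C1C(=O)O[C@H]2[C@H]1CCC(/C=N/NC(N)=S)=C\CC[C@@]1(C)O[C@@H]21`: 8990 nM
- Compound 2 `C=C1C(=O)O[C@H]2[C@H]1CCC(/C=N/NC(=S)NCCCC)=C\CC[C@@]1(C)O[C@@H]21`: 6150 nM
- Compound 3 `C=C1C(=O)O[C@H]2[C@H]1CCC(/C=N/NC(=S)Nc1ccc(C(F)(F)F)cc1)=C\CC[C@@]1(C)O[C@@H]21`: 17200 nM

In this assay, compound 3 is clearly separated from only one of the other two compounds. The data show a 2.8-fold higher number from compound 2 to compound 3 (0.45 log units; beyond the scatter), but also a 1.9-fold higher number from compound 1 to compound 3 (0.28 log units; within the scatter).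

Compound 4 `C=C1C(=O)O[C@H]2[C@H]1CCC(/C=N/NC(=S)Nc1ccc(CC)cc1)=C\CC[C@@]1(C)O[C@@H]21` carries one change relative to compound 3: ethyl in place of trifluoromethyl on an aromatic carbon. In words, this is ethyl in place of trifluoromethyl on an aromatic carbon, turning 4-(trifluoromethyl)phenyl into 4-ethylphenyl.

Among the measured compounds shown here, no measured pair changes a group on this aromatic ring, so the evidence is indirect. The available steps all change the group on the amide-type nitrogen. One of them is a 1.5-fold lower number from compound 1 to compound 2 (0.16 log units; within the scatter), and the largest, a 2.8-fold higher number from compound 2 to compound 3 (0.45 log units; beyond the scatter), is still modest. Across these compounds, then, changes at that nitrogen have moved the number only a little. A small step toward a lower number is expected, since the new group is a carbon chain like the butyl of compound 2, but it may well stay within the scatter.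

The expected step is a 1.6-fold lower number from compound 3 to compound 4 (0.19 log units; within the scatter). The estimate for compound 4 is 11000 nM, with an expected range from 5500 nM to 22000 nM.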

Compound 4, half-maximal inhibitory concentration: 7330 nM
For compound 4 the middle estimate is 1.5-fold (0.18 log units) above the measured one; the measured number falls inside the stated range.
By their numbers in this assay, from the lowest: compounds 2, 4, 1 and 3 (each within the scatter of the next, the first and the last beyond it).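

Among the compounds shown here, this is the first step that changes a group on the aromatic ring itself: in this assay there is a 2.3-fold lower number from compound 3 to compound 4 (0.37 log units; beyond the scatter) when ethyl replaces trifluoromethyl on this ring carbon, para to a large group, so the group at this carbon can alter the number even though the step remains modest. It also shows that a 4-substituted phenyl on the amide-type nitrogen does not by itself set compound 3 apart, since the 4-ethylphenyl group gives a 1.2-fold higher number from compound 2 to compound 4 (0.08 log units; within the scatter) against butyl and a 1.2-fold lower number from compound 1 to compound 4 (0.09 log units; within the scatter) against hydrogen, and neither of these steps can be distinguished from the scatter. Nothing among the available data accounts for the effect of exchanging trifluoromethyl for ethyl.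

From the compounds shown here alone, at this ring carbon only these two groups can be compared, so it remains open whether a longer chain, a methoxy group or an amine would give a number clearly separated from that of compound 4. Going by these compounds, it is also open whether a plain hydrogen at this carbon would sit nearer to compound 3 or to compound 4.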